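The source may hold more compounds than are shown below. What is called first, only, known or untested is meant among the compounds shown, and "the series" means these compounds.

Measured compounds in an assay on isolated protein for displacement of a labelled ligand from metabotropic glutamate receptor 5 (Homo sapiens), with a stated time of 60 min, tested at 1 uM; on this read-out lower numbers stand for less inhibition and higher numbers for more inhibition at the one concentration tested (going by the name of the read-out):
compound 1, `CC1CCN(c2c(S(=O)(=O)c3ccc(C#N)cc3)cnc3cc(F)ccc23)CC1`, gives 83%
compound 2, `CC1CCN(c2c(S(=O)(=O)c3ccc(Cl)cc3)cnc3cc(F)ccc23)CC1`, gives 90%
compound 3, `CC1CCN(c2c(S(=O)(=O)c3ccc(F)cc3)cnc3cc(F)ccc23)CC1`, gives 74.5%

Compound 3 holds the lowest of the three numbers shown, though its gap to compound 1 is within the scatter, as the step of a number 8.5 percentage points lower from compound 1 to compound 3 (within the scatter) tells; only the step of a number 15.5 percentage points lower from compound 2 to compound 3 (beyond the scatter) lies beyond the scatter. The step of a number 7 percentage points higher from compound 1 to compound 2 (within the scatter) is itself within the scatter.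

Compound 4, `CC1CCN(c2c(S(=O)(=O)c3cc(Cl)cc(Cl)c3)cnc3cc(F)ccc23)CC1`, differs from compound 3 as follows: 3,5-dichlorophenyl in place of 4-fluorophenyl on a sulfonyl sulfur. For the measured compounds named here, the one measured step that bears on it is a number 15.5 percentage points lower from compound 2 to compound 3 (beyond the scatter), in which the swap of the chlorine for a fluorine read lower; read backwards, the reverse swap would point upward by a modest amount. Going by the values given here, no measured pair covers two chlorines, nor the change of their place on the ring, so that part of the change is uncovered. In this assay a modest rise or none beyond the scatter is therefore expected, namely a step of a number 7.5 percentage points higher from compound 3 to compound 4 (within the scatter). Compound 4 is estimated at 82%, with a range from 60% to 96%.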

Compound 4, a percentage reported as inhibition, at one concentration (the size of the read-out at that concentration, not a potency): 87%
Compound 4: middle estimate off by 5 percentage points, on the low side, and the stated range covers the measured number.
By their numbers in this assay, from the lowest: compounds 3, 1, 4 and 2 (each within the scatter of the next, the first and the last beyond it).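

Placed on the sulfonyl sulfur in this assay, 3,5-dichlorophenyl gives a number 12.5 percentage points higher from compound 3 to compound 4 (beyond the scatter), so this two-chlorine ring, like the 4-chlorophenyl of compound 2, stands beyond the scatter from the 4-fluorophenyl of compound 3. The change from a single substituent to two chlorines separates compound 4 from neither of the other two aryl groups, as shown by a number 3 percentage points lower from compound 2 to compound 4 (within the scatter) and by a number 4 percentage points higher from compound 1 to compound 4 (within the scatter), which leaves compound 1 and compound 4 unresolved as well. No measurement on hand accounts for these steps.

Every group shown on the sulfonyl sulfur is a substituted phenyl bearing halogen or nitrile, so a carboxylic acid or an amine on that ring, or a saturated ring such as cyclohexyl in its place, remains open. With a single tested concentration, the compounds within the scatter of each other also remain unranked.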